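Working notes on thioether analogues in cell cytotoxicity

A few compounds are considered here, and "the series" means these few. Any claim that something is new, unique, unknown or untested is made for them only; others in the source may bear on it.

Measured so far in a functional assay on SGC-7901 cells (Homo sapiens) for cytotoxicity, read by MTT assay, with a stated time of 48 h; on this read-out lower numbers stand for stronger inhibition and higher numbers for weaker inhibition:
compound 1, `CCCCSCC(=O)N1N=C(c2cc3ccccc3oc2=O)C[C@@H]1c1ccc(C(F)(F)F)cc1`: 2910 nM
compound 2, `CC1=NN(C(=O)CSc2nc3ccccc3s2)[C@@H](c2cc(Br)cc(Br)c2O)C1`: 12300 nM
compound 3, `O=C(CSc1ccccc1)N1N=C(c2cc3ccccc3oc2=O)C[C@@H]1c1ccccc1`: 20300 nM

Compound 2 stands second highest of the three numbers. Its nearest neighbour is compound 3, whose number is higher by an amount within the usual scatter, so no order between compound 2 and compound 3 is drawn. Compound 1 sits furthest away, with a lower number beyond the scatter. Among the measured compounds shown here, no pair of measured compounds differs in only one place, so the step considered here rests on the structural change alone.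

Compound 4, `CC1=NN(C(=O)CSc2ccc(Br)cc2)[C@@H](c2cc(Br)cc(Br)c2O)C1`, has not yet been measured in this assay. It differs from compound 2 in one place: 4-bromophenyl in place of 1,3-benzothiazol-2-yl on a sulfur

Compound 3 gave the highest number and compound 1 the lowest, but each differs from compound 2 in more than one place, so neither fixes the direction of the present change. The estimated step is a 1.1-fold higher number from compound 2 to compound 4 (0.06 log units; within the scatter), within the scatter and with no firm direction. Compound 4 is expected to give about 14000 nM in this assay, with a range from 5000 nM to 40000 nM.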

Compound 4, half-maximal inhibitory concentration: 8210 nM
Beside the measured number, compound 4's estimate is 1.7-fold (0.23 log units) above it; the measured number falls inside the stated range.
By their numbers in this assay, from the lowest: compound 1; then compounds 4, 2 and 3 (each within the scatter of the next, the first and the last beyond it).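

In this assay, among the compounds shown here, 4-bromophenyl in place of 1,3-benzothiazol-2-yl on a sulfur gives a 1.5-fold lower number from compound 2 to compound 4 (0.18 log units; within the scatter), the first step in this set that rests on a change in one place only. At this position, on a sulfur whose other neighbour is a saturated chain carbon, the two groups therefore cannot be told apart, and neither can be ranked above the other: the fused pair of aromatic rings with its hetero atoms and hydrogen-bond acceptors is replaced by one six-membered aromatic ring of carbon only, with bromine and no hydrogen-bond acceptors, and the read-out stays within the scatter. Nothing available here bears on why the two groups read alike.

Steps to compound 1 and compound 3 cannot be read, as each differs from compound 2 and compound 4 in more than one place, so it remains unknown whether this result carries over to the core those two compounds share. Also open, going by these compounds, is how the same position on the core of compound 2 would respond to a group of another kind on the sulfur, such as a butyl chain, an amine or a carboxylic acid.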